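Trifluoromethyl-bearing fused core: amine replaced by hydrazine

The compounds below may be only part of what the source reports. "The series", "measured", "known", "first", "only" and "open" are said of these compounds alone.

Three compounds share one core and differ only in the group on the five-membered ring. Compound 1 `C=CCNc1nn2c(=O)cc(C(F)(F)F)nc2s1` gives 290 nM in an assay on cells for inhibition of alkaline phosphatase, tissue-nonspecific isozyme (Homo sapiens), read by luminescence, with stated times of 7 min and 20 min; on this read-out lower numbers stand for stronger inhibition and higher numbers for weaker inhibition. Compound 2 `CCCCNc1nn2c(=O)cc(C(F)(F)F)nc2s1` gives 880 nM, and compound 3 `CN(C)CCNc1nn2c(=O)cc(C(F)(F)F)nc2s1` gives 450 nM. Compound 2 carries the highest of the three numbers; the step of a 3.0-fold higher number from compound 1 to compound 2 (0.48 log units; beyond the scatter) lies beyond the scatter, while the step of a 2.0-fold lower number from compound 2 to compound 3 (0.29 log units; within the scatter) and the step of a 1.6-fold higher number from compound 1 to compound 3 (0.19 log units; within the scatter) stay within it, so compound 2 and compound 3 are not separated.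

Compound 4 `CN(N)c1nn2c(=O)cc(C(F)(F)F)nc2s1` is the next candidate; the change from compound 2 is amino(methyl)amino in place of butylamino on an aromatic carbon. Among the compounds with values here, all measured steps alter the chain on the ring-bound nitrogen and keep that nitrogen; none replaces the butylamino group as a whole, so no step bears on this change directly. The measured steps stay modest, between the scatter and the size of a 3.0-fold higher number from compound 1 to compound 2 (0.48 log units; beyond the scatter). A modest step in this assay is therefore expected, with a lean towards a lower number, estimated as a 1.6-fold lower number from compound 2 to compound 4 (0.20 log units; within the scatter). For compound 4 the expected value is 550 nM, with a range from 200 nM to 1600 nM.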

Compound 4, half-maximal inhibitory concentration: 2020 nM
Estimate against measurement, compound 4: 3.7-fold (0.56 log units) below; the whole stated range lies below it.
By their numbers in this assay, from the lowest: compounds 1, 3 and 2 (each within the scatter of the next, the first and the last beyond it); then compound 4.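

Amino(methyl)amino on the aromatic carbon is the only change in this series that gives a number beyond the scatter from all three other compounds in this assay (the steps are a 2.3-fold higher number from compound 2 to compound 4 (0.36 log units; beyond the scatter), a 4.5-fold higher number from compound 3 to compound 4 (0.65 log units; beyond the scatter) and a 7.0-fold higher number from compound 1 to compound 4 (0.84 log units; beyond the scatter)). Within the data shown here, changing the whole group therefore matters more here than the chain changes among compound 1, compound 2 and compound 3, of which only the step between compound 1 and compound 2 lies beyond the scatter. The smaller group, with 3 heavy atoms against 5 in butylamino, gives no lower number, so fewer heavy atoms alone do not lower the number in these compounds.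

A methylamino or an unsubstituted hydrazinyl group on the same carbon would show whether the methyl or the terminal amino accompanies the rise. No measurement shown gives a reason for the rise.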